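From Methyl to Diethylamino on Compound 2

The compounds below may be only part of what the source reports. "The series", "measured", "known", "first", "only" and "open" are said of these compounds alone.

Compounds measured in a functional assay on Daoy cells (Homo sapiens) for antiproliferative activity, read by trypan blue exclusion and crystal violet staining, with a stated time of 72 h; a higher number here means a weaker inhibitor, a lower number a stronger inhibitor:
Compound 1 `O=C(NCc1ccc2cccnc2c1O)C1CCCCC1`: 720 nM
Compound 2 `CCCC(=O)NC(c1ccc(C)cc1)c1cc(Cl)c2cccnc2c1O`: 100 nM
Compound 3 `CCCCC(=O)NCc1ccc2cccnc2c1O`: "nd" (no result reported)

Of the two numbers available, compound 2 has the lower at 100 nM, and compound 1 stands at 720 nM, a gap beyond the usual scatter. Compound 3 adds no number to this comparison.

The next compound is compound 4 `CCCC(=O)NC(c1ccc(N(CC)CC)cc1)c1cc(Cl)c2cccnc2c1O`, which differs from compound 2 by one change: diethylamino in place of methyl on an aromatic carbon. Diethylamino takes the place of methyl on an aromatic carbon, para to a large group. Among the compounds with values here, no pair of measured compounds differs in one place, so the data do not show what a change of this kind does in this assay. The expectation therefore rests on compound 2 at 100 nM, and no step beyond the scatter is expected in either direction. The estimated change is a 1.2-fold higher number from compound 2 to compound 4 (0.08 log units; within the scatter). For compound 4 the expected value is 120 nM. The estimated range for compound 4 runs from 35 nM to 400 nM.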

Compound 4, half-maximal inhibitory concentration: 100 nM
Beside the measured number, compound 4's estimate is 1.2-fold (0.08 log units) above it; the range from low to high includes it.
By their numbers in this assay, from the lowest: compounds 2 and 4 (each within the scatter of the next); then compound 1.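

Replacing methyl with diethylamino on an aromatic carbon, para to a large group, gives in this assay no change at the digits printed from compound 2 to compound 4 (within the scatter). Within the data shown here, this is the first comparison of two compounds differing in one place, which the earlier compounds could not provide, and it shows that this position accepts diethylamino, with 5 heavy atoms in place of 1 and a hydrogen-bond acceptor where methyl has none, without a step beyond the scatter. Nothing at hand gives a reason for this result.

From the compounds shown here alone, whether a carboxylic acid, a primary amine or a longer alkyl chain at this position would behave in the same way remains open. A single step at one position also leaves open how the same change would read out on the core of compound 1, which has no counterpart with diethylamino among the compounds shown.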